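A few compounds are considered here, and "the series" means these few. Any claim that something is new, unique, unknown or untested is made for them only; others in the source may bear on it.

Measured compounds:
compound 1 `COc1ccc(-c2cc(-c3ccc(F)cc3)nc(NC(=O)N/N=C\c3ccc([N+](=O)[O-])cc3)n2)cc1OC`, 300 mg/kg
compound 2 `C/C(=N/NC(=O)Nc1nc(-c2ccc(F)cc2)cc(-c2ccc([N+](=O)[O-])cc2)n1)c1ccc(C)cc1`, 300 mg/kg

Of the compounds shown here, two have been tested in a functional assay on the whole organism (strain Albino) with Mus musculus as the target, with a stated time of 0.5 h; a higher number here means that more compound is needed for the effect, a lower number that less compound is needed. Compound 1 gives 300 mg/kg in this assay, and compound 2 gives 300 mg/kg. Compound 2 therefore stands level with compound 1 at the digits recorded, the two values lying within the scatter of each other, so nothing can be said about an order between them.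

Compound 3 `COc1ccc(/C(C)=N\NC(=O)Nc2nc(-c3ccc(F)cc3)cc(-c3ccc([N+](=O)[O-])cc3)n2)cc1` is not yet measured. It differs from compound 2 in one place: methoxy in place of methyl on an aromatic carbon, on an aromatic carbon of a six-membered aromatic ring of carbon only, para to a large group. Cut one bond further out, the same difference reads 4-methylphenyl to 4-methoxyphenyl.

Among the compounds with values here, no step between measured compounds that differ in one place is available, so there is no measured change of this kind to lean on. The two values that exist are the same at the digits recorded, and a small exchange of this kind, a methyl for a methoxy, is expected to give no step beyond the scatter in this assay. Compound 3 is therefore expected to give 300 mg/kg, within 150 mg/kg to 600 mg/kg, and the step from compound 2 to compound 3 is estimated as no change at the digits printed from compound 2 to compound 3 (within the scatter).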

Compound 3, dose for half-maximal effect: 100 mg/kg
The estimate for compound 3 lay 3.0-fold (0.48 log units) above the measured number, outside the stated range (below it).
By their numbers in this assay, from the lowest: compound 3; then compounds 1 and 2 (each within the scatter of the next).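

In this assay, methoxy in place of methyl on an aromatic carbon, para to a large group, gives a 3.0-fold lower number from compound 2 to compound 3 (0.48 log units; beyond the scatter), and this is the only step shown between compounds that differ in one place. It shows that this position is not indifferent to what stands on it: going from 4-methylphenyl to 4-methoxyphenyl, with one more oxygen and one hydrogen-bond acceptor, moves the dose needed beyond the scatter towards less compound, although this is a modest step and rests on a single pair. Nothing at hand explains the step, so the result stands as an observation on this one pair.

It remains open whether the step belongs to the oxygen itself or simply to a longer group in this place, since only methyl and methoxy are shown here, and a hydroxyl group, an ethoxy group or an amine on the same aromatic carbon would help to tell these readings apart. Going by these compounds, it also remains open whether the same exchange would give a similar step with other groups elsewhere on the shared core.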